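Thiophen-3-yl for 3-nitrophenyl: notes on the series

The compounds below may be only part of what the source reports. "The series", "measured", "known", "first", "only" and "open" are said of these compounds alone.

Measured in a functional assay on HT-29 cells (Homo sapiens) for antiproliferative activity, read by MTT assay, with a stated time of 24 h; a higher number here means a weaker inhibitor, a lower number a stronger inhibitor:
- compound 1 `COc1ccc(C(=O)/C=C/c2ccc(N(C)C)cc2)c2c1C=CC(C)(C)O2`: 1870 nM
- compound 2 `COc1ccc(C(=O)/C=C/c2cccc([N+](=O)[O-])c2)c2c1C=CC(C)(C)O2`: 4260 nM

Compound 2, at 4260 nM, holds the higher of the two numbers, and compound 1 stands at 1870 nM. Compound 3 `COc1ccc(C(=O)/C=C/c2ccsc2)c2c1C=CC(C)(C)O2` differs from compound 2 in one place, on a double-bonded chain carbon bound to a double-bonded chain carbon: thiophen-3-yl in place of 3-nitrophenyl on a double-bonded chain carbon bound to a double-bonded chain carbon. Going by the values given here, one measured step bears on this place: a 2.3-fold higher number from compound 1 to compound 2 (0.36 log units; beyond the scatter), a modest step, beyond the scatter. Among the compounds with values here, no measured compound carries thiophen-3-yl, so the direction is poorly supported. Within the data shown here, a similar or smaller move in this assay toward a lower number is expected because compound 2 at 4260 nM is the higher of only two values. The expected change is a 1.4-fold lower number from compound 2 to compound 3 (0.15 log units; within the scatter). The estimate for compound 3 is 3000 nM, with an expected range of 1200 nM to 7500 nM.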

Compound 3, half-maximal inhibitory concentration: > 10000 nM
Compound 3: a limit, no number; the forecaster's own chance of this, stated with the estimate: 5%; at least 3.3-fold (0.52 log units) between middle value and limit.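

In this assay compound 3 gives > 10000 nM, a limit of the assay and not a number. Until now this place on a double-bonded chain carbon bound to a double-bonded chain carbon had shown only a modest step between two substituted phenyl groups, whereas thiophen-3-yl brings a larger loss, with an at least 2.3-fold higher number from compound 2 to compound 3 (0.37 log units; beyond the scatter) and an at least 5.3-fold higher number from compound 1 to compound 3 (0.72 log units; beyond the scatter). The place is therefore not indifferent to the group it carries, and of the three compounds only compound 3 falls outside the measurable range: the limit of > 10000 nM in this assay, at which 1 of the 3 values shown sits.

The compounds shown leave open whether the loss follows the thiophen-3-yl ring itself or the lack of any substituent on it; a plain phenyl or a furan-3-yl at this place would bear on that question. As far as these compounds go, how far compound 3 lies past its limit also remains unknown.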